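A few compounds are considered here, and "the series" means these few. Any claim that something is new, unique, unknown or untested is made for them only; others in the source may bear on it.

Measured so far in a functional assay on NFS-60 cells (Mus musculus) for inhibition, read by MTT assay, with a stated time of 72 h; a lower number here means a stronger inhibitor, a higher number a weaker inhibitor: compound 1 `Cc1ccc(C(=O)OC2(C(=O)Nc3ccc([N+](=O)[O-])cc3)CCCCC2)cc1` gives 45.4 nM, compound 2 `O=C(OC1(C(=O)Nc2ccc([N+](=O)[O-])cc2)CCCCC1)c1ccc([N+](=O)[O-])cc1` gives 7.7 nM, and compound 3 `O=C(OC1(C(=O)Nc2ccc([N+](=O)[O-])cc2)CCCCC1)C(O)c1ccccc1` gives 7.8 nM.

Compound 3 stands second highest of the three numbers: its distance to compound 2 is within the scatter (a 1.0-fold higher number from compound 2 to compound 3 (0.01 log units; within the scatter)), while compound 1 sits apart (a 5.8-fold lower number from compound 1 to compound 3 (0.76 log units; beyond the scatter)). Compound 4 `CC(=O)Oc1ccccc1C(=O)OC1(C(=O)Nc2ccc([N+](=O)[O-])cc2)CCCCC1` changes the ester group: 2-acetoxyphenyl in place of hydroxy(phenyl)methyl on a carbonyl carbon. The steps at that carbonyl carbon are a 5.8-fold lower number from compound 1 to compound 3 (0.76 log units; beyond the scatter) and a 1.0-fold higher number from compound 2 to compound 3 (0.01 log units; within the scatter), and the two aryl esters differ by a 5.9-fold lower number from compound 1 to compound 2 (0.77 log units; beyond the scatter). Among the measured compounds shown here, no measured compound carries an acetoxy group on the ring, so the direction of this change is open, and only a modest step is expected, as a 1.9-fold higher number from compound 3 to compound 4 (0.28 log units; within the scatter). Compound 4 is estimated at 15 nM, with a range of 5 nM to 60 nM.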

Compound 4, half-maximal inhibitory concentration: 11.3 nM
Beside the measured number, compound 4's estimate is 1.3-fold (0.12 log units) above it; measured number inside the range.
By their numbers in this assay, from the lowest: compounds 2, 3 and 4 (each within the scatter of the next); then compound 1.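

In this assay, 2-acetoxyphenyl on the carbonyl carbon stays within the scatter of both hydroxy(phenyl)methyl (a 1.4-fold higher number from compound 3 to compound 4 (0.16 log units; within the scatter)) and 4-nitrophenyl (a 1.5-fold higher number from compound 2 to compound 4 (0.17 log units; within the scatter)). An ester group with 0 hydrogen-bond donors therefore matches one with 1 donor, and an aryl ester with a substituent other than nitro also falls in this group. Compound 1, with 4-methylphenyl, remains apart (a 4.0-fold lower number from compound 1 to compound 4 (0.60 log units; beyond the scatter)), and no measurement available here explains the difference.

Open is whether the acetoxy group contributes at all, since a plain phenyl or a free hydroxy group on the ring is not among the compounds shown. Going by these compounds, an amine or a carboxylic acid on that ring also remains untested in this set.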